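This account rests on a few compounds, and the source may have more. Where it says the series, first, only, none or still open, it means among the compounds named here.

In a functional assay on B16-F10 cells (Mus musculus) for cytotoxicity, read by MTT assay, with a stated time of 48 h (a lower number here means a stronger inhibitor, a higher number a weaker inhibitor), compound 1 `COc1cc(CN(C(=O)Nc2ccc(C)cc2)n2cnnc2)cc(OC)c1OC` gives 46800 nM. Compound 2 `Cc1ccsc1CN(C(=O)Nc1cccc(C#N)c1)n1cnnc1` gives 28900 nM in this assay, and these two numbers lie within the ordinary scatter of each other, so neither compound can be set above the other. Compound 3 `Cc1ccsc1CN(C(=O)Nc1cccc(Cl)c1)n1cnnc1` is recorded in this assay only as a limit, > 50000 nM, which is the limit of > 50000 nM in this assay, at which 1 of the 3 values shown sits. Within the data shown here, the single measured step, an at least 1.7-fold higher number from compound 2 to compound 3 (0.23 log units; that floor lies within the scatter), concerns the other end of the molecule and not the place where compound 1 and compound 4 `COc1ccc(CN(C(=O)Nc2ccc(C)cc2)n2cnnc2)cc1OC` differ. The change from compound 1 to compound 4 is hydrogen in place of methoxy on an aromatic carbon. Among the measured compounds shown here, no measured step bears on this change, and the narrow spread of the numbers at hand gives no ground for a shift in either direction. Compound 4 is therefore expected to land near compound 1, with a 1.1-fold higher number from compound 1 to compound 4 (0.03 log units; within the scatter) amounting to no more than the scatter. The estimate for compound 4 in this assay is 50000 nM, with a range from 20000 nM to 150000 nM.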

Compound 4, half-maximal inhibitory concentration: 29900 nM
For compound 4 the middle estimate is 1.7-fold (0.22 log units) above the measured one, within the range that was stated.
By their numbers in this assay, from the lowest: compounds 2, 4 and 1 (each within the scatter of the next). At a limit, above all of these: compound 3.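

Among these compounds, the step from methoxy to hydrogen, a 1.6-fold lower number from compound 1 to compound 4 (0.19 log units; within the scatter), is the first measured one at this place, an aromatic carbon ortho to a methoxy group and meta to a large group. It shows that in this assay this methoxy group can give way to hydrogen without a shift that stands clear of the scatter, so no share of the cytotoxicity can be assigned to it from these data. The set still holds one limit rather than a number, that of compound 3: the limit of > 50000 nM in this assay, at which 1 of the 4 values shown sits.

As far as these compounds go, it remains open whether another group at this place, such as an amine, a carboxylic acid or a longer alkoxy chain, would move the number beyond the scatter. Also open, from the compounds shown here alone, is whether hydrogen would read the same way at the other methoxy groups of the ring.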